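From bromo to trifluoromethyl: estimating compound 4

This account rests on a few compounds, and the source may have more. Where it says the series, first, only, none or still open, it means among the compounds named here.

compound 1 `COc1cc(Cl)ccc1C(=O)Nc1cc(Br)ccc1O` gives 5630 nM
compound 2 `COc1cc(Cl)ccc1C(=O)Nc1ccc(C(F)(F)F)cc1O` gives 3900 nM
compound 3 `COc1ccc(Cl)cc1C(=O)Nc1cc(Br)ccc1O` gives 4090 nM

These three compounds were all tested in a functional assay on HepG2 cells (Homo sapiens) for cytotoxicity, with a stated time of 24 h (on this read-out lower numbers stand for stronger inhibition and higher numbers for weaker inhibition), and their numbers lie close together. Compound 3 at 4090 nM stands within the usual scatter of both compound 1 and compound 2, so repeat measurements alone could produce gaps of this size. No order among them can be read from these data.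

The next compound changes one group of compound 3. Compound 4 `COc1ccc(Cl)cc1C(=O)Nc1cc(C(F)(F)F)ccc1O` has trifluoromethyl in place of bromo on an aromatic carbon and is otherwise identical to compound 3. Among the measured compounds shown here, no measured pair shows this swap on its own, so there is no direct guide to its size. The closest clue is compound 2 at 3900 nM which also carries trifluoromethyl and still falls within the scatter of the two bromo compounds. On that basis, no step beyond the scatter is expected in this assay and no direction is favoured. The expected change is a 1.1-fold lower number from compound 3 to compound 4 (0.03 log units; within the scatter) and it would be too small to separate the two compounds. The estimate for compound 4 is 3800 nM with an expected range from 1800 nM to 8000 nM for a single measurement.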

Compound 4, half-maximal inhibitory concentration: 15400 nM
Compound 4: the middle estimate sits 4.1-fold (0.61 log units) below what was measured, outside the stated range (above it).
By their numbers in this assay, from the lowest: compounds 2, 3 and 1 (each within the scatter of the next); then compound 4.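

In this assay, among the compounds shown here, putting trifluoromethyl in place of bromo on this aromatic carbon, para to a hydroxy group and meta to a large group, is not a silent swap: the single change gives a 3.8-fold higher number from compound 3 to compound 4 (0.58 log units; beyond the scatter) and so means weaker inhibition. The earlier compounds shown here allowed no order, as their numbers all lay within the scatter of one another, whereas this pair gives the first gap in the set that is beyond the scatter. The pair fixes the size and direction of this one step, but no measurement available here accounts for it.

The compounds shown leave open whether the same swap would give a similar step in compound 1, where the chloro and methoxy groups are arranged differently on the other ring. They also leave open how other groups on this carbon would compare, such as a nitrile, a methyl group or an amine, and so whether bromo is unusually favourable here or trifluoromethyl unusually unfavourable.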